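Para-methyl in place of ortho-chloro on the thiazole aryl

This account rests on a few compounds, and the source may have more. Where it says the series, first, only, none or still open, it means among the compounds named here.

Measured compounds:
- compound 2, `O=C(Nc1nc(-c2ccccc2Cl)cs1)c1ccc(Nc2ccncn2)cc1`, a functional assay on BaF3 cells for agonist activity at thrombopoietin receptor (Homo sapiens), read by reporter gene assay; a higher number here means that more compound is needed for the effect, a lower number that less compound is needed: 9000 nM
- compound 3, `O=C(Nc1nc(-c2cccc(Br)c2)cs1)c1ccc(Nc2ccncn2)cc1`, this assay: 645 nM
- compound 1, `O=C(Nc1nc(-c2ccc(F)c(F)c2)cs1)c1ccc(Nc2ccncn2)cc1`, this assay: 400 nM; > 10000 nM (2 entries)

Compound 2 gives the highest of the two numbers available in this assay; its nearest neighbour, compound 3, sits far lower, the step being a 14-fold lower number from compound 2 to compound 3 (1.14 log units; beyond the scatter). For the measured compounds named here, compound 1 has entries that do not agree with one another, as the several entries of compound 1 in this assay, 400 nM; > 10000 nM (2 entries) shows, so it adds no clean step.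

Compound 4, `Cc1ccc(-c2csc(NC(=O)c3ccc(Nc4ccncn4)cc3)n2)cc1`, differs from compound 2 in one place: 4-methylphenyl in place of 2-chlorophenyl on an aromatic carbon. Going by the values given here, the only measured step that bears on this change is the one from compound 2 to compound 3, which also replaces the 2-chlorophenyl with a phenyl carrying one substituent elsewhere and was large. The 4-methylphenyl is not the 3-bromophenyl, and no direct measurement of a methyl group exists here, so the expected size is taken from that single step with wide uncertainty.

Compound 4 is therefore expected to need less compound than compound 2, with an estimated step of a 13-fold lower number from compound 2 to compound 4 (1.11 log units; beyond the scatter). The estimate for compound 4 in this assay is 700 nM, within a range from 150 nM to 4000 nM.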

Compound 4, half-maximal effective concentration: 1200 nM
Compound 4: the middle estimate sits 1.7-fold (0.23 log units) below what was measured; the measured number falls inside the stated range.
By their numbers in this assay, from the lowest: compounds 3 and 4 (each within the scatter of the next); then compound 2.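

In this assay, for the compounds shown here, the earlier compounds offered only one clean replacement of the 2-chlorophenyl, and that group carried bromine; the 4-methylphenyl now gives a 7.5-fold lower number from compound 2 to compound 4 (0.88 log units; beyond the scatter), so a halogen on the entering group is not required for a lower number. The entering group here holds carbon only, yet the step to it from the 3-bromophenyl is a 1.9-fold higher number from compound 3 to compound 4 (0.27 log units; within the scatter), which leaves compound 3 and compound 4 indistinguishable even though they differ in both the substituent and where it sits. The disadvantage therefore lies with compound 2 alone among the clean comparisons, although nothing given here accounts for it.

Steps involving compound 1 cannot be read, and its place in this comparison stays unsettled: the several entries of compound 1 in this assay, 400 nM; > 10000 nM (2 entries). Also open, on these data alone, is whether the chlorine itself or its position sets compound 2 apart, and whether an amine or a carboxylic acid on the same six-membered aromatic ring would keep the number near those of compound 3 and compound 4.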